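Amine substituent variation on the shared core

The source may report more compounds than this note shows. Statements on the series, on what has been measured and on what is new or still open speak of the compounds shown alone.

Measured compounds:
compound 1 `CCCCNc1nc(C(F)(F)F)ccc1CNC(=O)C(C)c1ccc(NS(C)(=O)=O)c(F)c1` gives 9.1 nM
compound 2 `CC(C(=O)NCc1ccc(C(F)(F)F)nc1NC1CCCCC1)c1ccc(NS(C)(=O)=O)c(F)c1` gives 20.4 nM
compound 3 `CC(C(=O)NCc1ccc(C(F)(F)F)nc1Nc1ccc(F)cc1)c1ccc(NS(C)(=O)=O)c(F)c1` gives 39.2 nM

In a functional assay on CHO-K1 cells for antagonist activity at transient receptor potential cation channel subfamily V member 1 (Homo sapiens), read by FLIPR (a higher number here means a weaker inhibitor, a lower number a stronger inhibitor), compound 1 stands lowest of the three numbers, the strongest inhibitor here, with the steps to compound 2 and compound 3 both beyond the scatter.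

Compound 4 `CC(C(=O)NCc1ccc(C(F)(F)F)nc1NCc1ccccc1)c1ccc(NS(C)(=O)=O)c(F)c1` differs from compound 1 in phenyl in place of propyl on a saturated chain carbon bound to a nitrogen on an aromatic ring. Among the compounds with values here, two measured steps bear on it, each putting a ring in place of butyl on the same nitrogen: a 2.2-fold higher number from compound 1 to compound 2 (0.35 log units; beyond the scatter) and a 4.3-fold higher number from compound 1 to compound 3 (0.63 log units; beyond the scatter). Both raised the number modestly; the values of compound 2 and compound 3 lie within the scatter of each other. A modest rise is therefore expected for compound 4, a 2.2-fold higher number from compound 1 to compound 4 (0.34 log units; beyond the scatter). Compound 4 is estimated at 20 nM, with a range from 8 nM to 50 nM.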

Compound 4, inhibition constant: 15.8 nM
The estimate for compound 4 lay 1.3-fold (0.10 log units) above the measured number; the range from low to high includes it.
By their numbers in this assay, from the lowest: compounds 1, 4, 2 and 3 (each within the scatter of the next, the first and the last beyond it).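

In this assay, a benzyl on this nitrogen stands level with butyl (a 1.7-fold higher number from compound 1 to compound 4 (0.24 log units; within the scatter)) and with cyclohexyl (a 1.3-fold lower number from compound 2 to compound 4 (0.11 log units; within the scatter)), so an aromatic ring held on a saturated chain carbon fits this position as well as either saturated group. Only 4-fluorophenyl separates from it (a 2.5-fold lower number from compound 3 to compound 4 (0.39 log units; beyond the scatter)). No measurement at hand explains these steps.

That last step changes both the saturated chain carbon and the fluorine, and the compounds shown do not separate the two. A plain phenyl or a 4-fluorobenzyl on this nitrogen would bear on that question, and a phenethyl would test a longer chain.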